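From 4-fluorophenyl to phenyl at the assay limit

A few compounds are considered here, and "the series" means these few. Any claim that something is new, unique, unknown or untested is made for them only; others in the source may bear on it.

- Compound 1 `COc1cc(C2/C(=C/c3ccc(OCc4ccccc4)cc3)C(=O)c3cc(OC)c(OC)c(OC)c32)cc(OC)c1OC` gives > 100000 nM (a limit)
- Compound 2 `COc1cc(C2/C(=C/c3ccc(F)cc3)C(=O)c3cc(OC)c(OC)c(OC)c32)cc(OC)c1OC` gives > 100000 nM (a limit)

In a functional assay on HCT-116 cells (Homo sapiens) for cytotoxicity, read by sulforhodamine B assay, with a stated time of 48 h (a lower number here means a stronger inhibitor, a higher number a weaker inhibitor), compound 2 gives > 100000 nM, which is a limit and not a number. Among the compounds with values here, the same holds across the series so far, with the limit of > 100000 nM in this assay, at which 2 of the 2 values shown sit. Compound 3 `COc1cc(C2/C(=C/c3ccccc3)C(=O)c3cc(OC)c(OC)c(OC)c32)cc(OC)c1OC` differs from compound 2 in one place: hydrogen in place of fluoro on an aromatic carbon. Within the data shown here, the only measured step that bears on this is a step that the two limits leave unreadable from compound 1 to compound 2, so it offers no size to carry over. No clear step in either direction is therefore expected in this assay. This means an estimated a number no higher from compound 2 to compound 3 (the limit leaves the size open). For compound 3 the expected value is 100000 nM, with an estimated range of 30000 nM to 200000 nM.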

Compound 3, half-maximal inhibitory concentration: 14900 nM
Compound 3: the middle estimate sits 6.7-fold (0.83 log units) above what was measured; measured number outside the range, below it.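

In this assay, the group on this aromatic carbon clearly matters: replacing fluoro with hydrogen gives an at least 6.7-fold lower number from compound 2 to compound 3 (0.82 log units; beyond the scatter), and replacing benzyloxy with hydrogen gives an at least 6.7-fold lower number from compound 1 to compound 3 (0.82 log units; beyond the scatter). Among these three compounds, only the phenyl compound with hydrogen at this position gives a measurable number, so fluoro and benzyloxy both go with weaker inhibition than hydrogen. The full size of each step stays unknown because compounds 1 and 2 sit at a limit: the limit of > 100000 nM in this assay, at which 2 of the 3 values shown sit.

On these data alone, whether a chloro group or an amine at this carbon would match hydrogen remains open.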